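A few compounds are considered here, and "the series" means these few. Any claim that something is new, unique, unknown or untested is made for them only; others in the source may bear on it.

Working notes on the series. Compound 1 `CC[C@H](CCn1cncn1)c1ccccc1` gives 97.7 ug/mL in an ADME assay on HEp-2 cells (Homo sapiens) for cytotoxicity, read by MTT assay, with a stated time of 3 days; a higher number here means that more compound is tolerated, a lower number that less compound is tolerated. Compound 2 `CC[C@@H](CCn1cncn1)c1ccccc1` gives 89.9 ug/mL in this assay. The step of a 1.1-fold lower number from compound 1 to compound 2 (0.04 log units; within the scatter) is the only measured one in the set, and it is consistent with the fact that compounds 1 and 2 differ only in the configuration as drawn. Among the compounds with values here, on the numbers so far compound 2 holds the lower of the two values, with compound 1 nearest, the two lying within the scatter of each other.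

Compound 3 `c1ccc(C[C@@H](CCn2cncn2)c2ccccc2)cc1` has not yet been measured in this assay. Relative to compound 2 the change is phenyl in place of methyl on a saturated chain carbon, two bonds along the chain from an aromatic carbon. Within the data shown here, no measured step concerns this kind of change; the one step available, a 1.1-fold lower number from compound 1 to compound 2 (0.04 log units; within the scatter), concerns configuration only and gives no guide to the size or direction of an exchange of methyl for phenyl. The expectation for compound 3 therefore rests on compound 2 alone, with a wide range, and a step of a 1.4-fold lower number from compound 2 to compound 3 (0.14 log units; within the scatter) is estimated rather than a change beyond the scatter in either direction. Compound 3 is expected to give about 65 ug/mL in this assay, within 25 ug/mL to 160 ug/mL.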

Compound 3, half-maximal cytotoxic concentration: 55.9 ug/mL
Estimate against measurement, compound 3: 1.2-fold (0.07 log units) above, within the range that was stated.
By their numbers in this assay, from the lowest: compounds 3, 2 and 1 (each within the scatter of the next).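

In this assay the exchange of methyl for phenyl on a saturated chain carbon, two bonds along the chain from an aromatic carbon, is read as a 1.6-fold lower number from compound 2 to compound 3 (0.21 log units; within the scatter) and so stays within the scatter, even though ethyl becomes benzyl at this place. Within the data shown here, the earlier compounds spoke only to the configuration at this carbon, whereas compound 3 gives the first reading on the group it carries and shows that a six-membered aromatic ring of carbon only can stand here with no step beyond the scatter in this assay. Nothing at hand bears on why this step is of this size.

Still open, from the compounds shown here alone, is whether other groups at this place, such as an amine, a carboxylic acid or a longer chain, would also stay within the scatter of compound 2, since a single exchange cannot define a trend for the position. Also open, going by these compounds, is whether the configuration at this carbon counts for more with benzyl there than it does with ethyl in compounds 1 and 2.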